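The source may hold more compounds than are shown below. What is called first, only, known or untested is meant among the compounds shown, and "the series" means these compounds.

The compounds measured in an ADME assay on HT-29 cells (Homo sapiens) for inhibition, read by MTT assay, with a stated time of 72 h (on this read-out lower numbers stand for stronger inhibition and higher numbers for weaker inhibition), so far:
Compound 1 `C=CC(=O)Nc1cccc(Nc2nc(N/N=C/c3ccccc3F)ncc2Cl)c1` gives 3500 nM in this assay.
Compound 2 `C=CC(=O)Nc1cccc(Nc2nc(N/N=C(\C)c3ccncc3)ncc2Cl)c1` gives 12800 nM in this assay.
Compound 3 `CN(C)C/C=C/C(=O)Nc1cccc(Nc2nc(N/N=C/c3ccccc3F)ncc2Cl)c1` gives 3660 nM in this assay.

Among these three numbers compound 3 stands second highest; its nearest neighbour is compound 1, and the two lie within the scatter of each other, while compound 2 sits furthest away with a higher number. Compound 4 `COc1ccc(/C=N/Nc2ncc(Cl)c(Nc3cccc(NC(=O)/C=C/CN(C)C)c3)n2)cc1` is not yet measured; it differs from compound 3 by 4-methoxyphenyl in place of 2-fluorophenyl on a carbon with a double bond to nitrogen. Two measured steps help here. The swap of the whole aryl group on the hydrazone, a 3.7-fold higher number from compound 1 to compound 2 (0.56 log units; beyond the scatter), shows this region can move the number by a modest amount. The other step, a 1.0-fold higher number from compound 1 to compound 3 (0.02 log units; within the scatter), shows the amide end hardly matters. For compound 4 a modest shift is therefore expected, a 1.4-fold higher number from compound 3 to compound 4 (0.14 log units; within the scatter), with direction uncertain. Compound 4 is expected to give about 5000 nM, in the range 1800 nM to 14000 nM.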

Compound 4, half-maximal inhibitory concentration: 4820 nM
Compound 4: the middle estimate sits 1.0-fold (0.02 log units) above what was measured, and the stated range covers the measured number.
By their numbers in this assay, from the lowest: compounds 1, 3 and 4 (each within the scatter of the next); then compound 2.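

In this assay, 4-methoxyphenyl in place of 2-fluorophenyl on a carbon with a double bond to nitrogen gives a 1.3-fold higher number from compound 3 to compound 4 (0.12 log units; within the scatter) and so leaves the number within the scatter. Exchanging a fluorine-bearing ring for a larger methoxy-bearing one therefore makes no readable difference here, unlike the ring swap in a 3.7-fold higher number from compound 1 to compound 2 (0.56 log units; beyond the scatter) that went beyond the scatter. No measurement at hand offers a reason for this result. Still open, from the compounds shown here alone, is whether a phenyl ring carrying an amine or a carboxylic acid would move the number beyond the scatter.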